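A few compounds are considered here, and "the series" means these few. Any claim that something is new, unique, unknown or untested is made for them only; others in the source may bear on it.

Within the data shown here, in a functional assay on MCF7 cells (Homo sapiens) for cytotoxicity, read by MTT assay, with a stated time of 3 days (a lower number here means a stronger inhibitor, a higher number a weaker inhibitor), compound 1 (`COc1cccc(-c2cccc(O)c2)c1`) gives 33 ug/mL, the lowest of the two numbers measured so far. Compound 2 (`Nc1cccc(-c2cccc(O)c2)c1`) gives 99 ug/mL, and the exchange of its amino for the methoxy of compound 1 amounts to a 3.0-fold higher number from compound 1 to compound 2 (0.48 log units; beyond the scatter). Compound 3 (`COc1ccc(-c2cccc(O)c2)cc1OC`) has not yet been measured. It keeps the core of compound 1 and carries methoxy in place of hydrogen on an aromatic carbon. Among the measured compounds shown here, the one measured step, a 3.0-fold higher number from compound 1 to compound 2 (0.48 log units; beyond the scatter), replaces the methoxy group and adds none, so it bears only indirectly, though its modest size argues against expecting a large change. The step expected in this assay is therefore a 1.1-fold lower number from compound 1 to compound 3 (0.04 log units; within the scatter), not beyond the scatter, with no direction favoured. Compound 3 is expected at 30 ug/mL, with an estimated range from 12 ug/mL to 75 ug/mL.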

Compound 3, half-maximal inhibitory concentration: 48 ug/mL
Compound 3: the middle estimate sits 1.6-fold (0.20 log units) below what was measured, and the stated range covers the measured number.
By their numbers in this assay, from the lowest: compounds 1 and 3 (each within the scatter of the next); then compound 2.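

A second methoxy group on this aromatic carbon, ortho to a methoxy group and para to a group of 7 heavy atoms, gives in this assay no change that can be told from the scatter: a 1.5-fold higher number from compound 1 to compound 3 (0.16 log units; within the scatter). The earlier compounds shown here spoke only to replacing the existing methoxy group, where amino gave a change beyond the scatter, a 3.0-fold higher number from compound 1 to compound 2 (0.48 log units; beyond the scatter), and said nothing about this open aromatic carbon, which now proves able to carry methoxy with the number held within the scatter. No measured evidence is available to account for this result.

The compounds shown leave open whether a different group on this carbon, such as chlorine, an ethoxy group or a carboxylic acid, would also leave the number within the scatter. As far as these compounds go, it also remains open whether the added methoxy group would give the same result alongside the amino group of compound 2.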